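Tetrazole in place of pyrimidine on the shared core

This account rests on a few compounds, and the source may have more. Where it says the series, first, only, none or still open, it means among the compounds named here.

Compound 1 `Fc1ccccc1Cn1nc(-c2ccco2)c2cccnc21` gives 9300 nM in a functional assay (aorta) with Oryctolagus cuniculus as the target; a lower number here means a stronger inhibitor, a higher number a weaker inhibitor. Compound 2 `Fc1ccccc1Cn1nc(-c2ncccn2)c2cccnc21` gives 1250 nM in this assay, the lowest of the two single numbers; the step of a 7.4-fold lower number from compound 1 to compound 2 (0.87 log units; beyond the scatter) is the only measured one. Compound 3 `Nc1ccnc(-c2nn(Cc3ccccc3F)c3ncccc23)n1` has two entries in this assay, 270 nM; 265000 nM (2 entries), which do not agree (the several entries of compound 3 in this assay, 270 nM; 265000 nM (2 entries)), so it gives no single number to rank against.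

Compound 4 `Fc1ccccc1Cn1nc(-c2nn[nH]n2)c2cccnc21` differs from compound 2 by 2H-tetrazol-5-yl in place of pyrimidin-2-yl on an aromatic carbon. For the measured compounds named here, the measured step concerns a pyrimidine entering in place of a furan at the same position, not a tetrazole leaving a pyrimidine; no compound of the series carries a tetrazole, so nothing measured bears directly on the change. Going by the values given here, with only the step from compound 1 to compound 2 and the scattered entries of compound 3 at hand, a step of modest size in the weakening direction is expected, a 2.0-fold higher number from compound 2 to compound 4 (0.30 log units; within the scatter), with wide uncertainty. Compound 4 is therefore estimated at 2500 nM in this assay, within a range from 400 nM to 15000 nM.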

Compound 4, half-maximal inhibitory concentration: 8600 nM
Compound 4: middle estimate off by 3.4-fold (0.54 log units), on the low side; the range from low to high includes it.
By their numbers in this assay, from the lowest: compound 2; then compounds 4 and 1 (each within the scatter of the next).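

At this position on the shared core, replacing pyrimidin-2-yl with 2H-tetrazol-5-yl gives up the gain seen earlier, with a 6.9-fold higher number from compound 2 to compound 4 (0.84 log units; beyond the scatter) in this assay against a 7.4-fold lower number from compound 1 to compound 2 (0.87 log units; beyond the scatter) on the way in. The remaining pair shows a 1.1-fold lower number from compound 1 to compound 4 (0.03 log units; within the scatter), so among the three groups with single numbers, only pyrimidin-2-yl stands apart, while furan-2-yl and 2H-tetrazol-5-yl cannot be told apart in these data. Nothing at hand explains the loss on going to the tetrazole, since the only supporting entries concern the disagreement among the values for compound 3.

Open, on these data alone, is how a carboxylic acid or a pyridin-2-yl group would compare at this position. Also open, as far as these compounds go, is whether a methyl group on the tetrazole nitrogen would change the step seen with 2H-tetrazol-5-yl.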